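Second demethylation on the shared core of compound 2

This account rests on a few compounds, and the source may have more. Where it says the series, first, only, none or still open, it means among the compounds named here.

For the measured compounds named here, in a functional assay on NCI-H460 cells (Homo sapiens) for cytotoxicity, read by MTT assay, with a stated time of 48 h (a lower number here means a stronger inhibitor, a higher number a weaker inhibitor), compound 2 `COc1ccc2[nH]c(-c3ccccc3F)cc(=O)c2c1O` gives 110 nM, the only measured number. Compound 1 `COc1ccc2[nH]c(-c3ccccc3F)cc(=O)c2c1OC` gives > 20000 nM, which is a limit of the assay and not a number, as recorded at the limit of > 20000 nM in this assay, at which 1 of the 2 values shown sits.

Compound 3 `O=c1cc(-c2ccccc2F)[nH]c2ccc(O)c(O)c12` is not yet measured. It differs from compound 2 by hydrogen in place of methyl on an oxygen on an aromatic ring, read one bond further out as methoxy to hydroxy. Going by the values given here, the one measured step of the same kind is an at least 180-fold lower number from compound 1 to compound 2 (2.25 log units; beyond the scatter). That step removed the first of two methyls; the step to compound 3 removes the second, and the two measured compounds give no guide to whether such a gain repeats on the remaining oxygen. For compound 3 the expectation is a 1.4-fold higher number from compound 2 to compound 3 (0.13 log units; within the scatter), a change not beyond the scatter. Compound 3 is expected at 150 nM, with a range from 30 nM to 800 nM.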

Compound 3, half-maximal inhibitory concentration: 4100 nM
For compound 3 the middle estimate is 27-fold (1.44 log units) below the measured one; measured number above the stated range.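

The same change, methoxy to hydroxy on an oxygen on an aromatic ring, runs in opposite directions on the two oxygens of the shared core: in this assay there is an at least 180-fold lower number from compound 1 to compound 2 (2.25 log units; beyond the scatter), while the second demethylation gives a 37-fold higher number from compound 2 to compound 3 (1.57 log units; beyond the scatter), so among these compounds the single remaining methoxy of compound 2 goes with the strongest inhibition. The entry for compound 1, > 20000 nM, is a limit of the assay and not a number. Nothing measured here bears on the reason for this reversal.

Open, from the compounds shown here alone, is whether the remaining methoxy of compound 2 can be exchanged for an ethoxy group or an amine with its number of 110 nM kept. Also open, going by these compounds, is whether the first hydroxy can be exchanged for a carboxylic acid.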